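A few compounds are considered here, and "the series" means these few. Any claim that something is new, unique, unknown or untested is made for them only; others in the source may bear on it.

Compound 1 `N#CN1CC(OCc2ccc(-c3ccccc3)cc2)C1` carries the shared core with no substituent on its aromatic rings. In an assay on isolated protein for inhibition of N-acylethanolamine-hydrolyzing acid amidase (Homo sapiens), read by fluorescence, with a stated time of 90 min (on this read-out higher numbers stand for weaker inhibition and lower numbers for stronger inhibition), compound 1 gives 2.8 nM. For the measured compounds named here, compound 2 `N#CN1CC(OCc2ccc(-c3ccc(F)cc3)cc2)C1` adds a single fluorine on an aromatic carbon, and in this assay compound 2 gives 0.68 nM; the step of a 4.1-fold lower number from compound 1 to compound 2 (0.61 log units; beyond the scatter) is the only single change measured here. Compound 3 `COc1cccc(-c2ccc(COC3CN(C#N)C3)c(C(F)(F)F)c2)c1` differs more broadly, carrying a methoxy and a trifluoromethyl on aromatic carbons, and in this assay compound 3 gives 0.85 nM. Among the three numbers compound 3 stands second highest: its value and that of compound 2 lie within the usual scatter of each other, while compound 1 sits beyond the scatter above it. Compound 4 `COc1cccc(-c2ccc(COC3CN(C#N)C3)c(OC)c2)c1` is reached from compound 3 by the change (methoxy in place of trifluoromethyl on an aromatic carbon). Going by the values given here, no measured step here exchanges a trifluoromethyl for a methoxy, so the fluorine step from compound 1 to compound 2 offers no direct guide, and only a change of at most modest size in this assay is expected, in either direction. Compound 4 is therefore expected to give 1.5 nM, within 0.4 nM to 6 nM, which would mean an expected step of a 1.8-fold higher number from compound 3 to compound 4 (0.25 log units; within the scatter) that stays close to the scatter.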

Compound 4, half-maximal inhibitory concentration: 2.8 nM
Estimate against measurement, compound 4: 1.9-fold (0.27 log units) below, and the stated range covers the measured number.
By their numbers in this assay, from the lowest: compounds 2 and 3 (each within the scatter of the next); then compounds 1 and 4 (each within the scatter of the next).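

On the aromatic carbon ortho to the ((1-cyanoazetidin-3-yl)oxy)methyl group, the group present clearly affects the result in this assay: methoxy in place of trifluoromethyl gives a 3.3-fold higher number from compound 3 to compound 4 (0.52 log units; beyond the scatter). For the compounds shown here, this is the first measured change at this position, and it shows that the two groups cannot be exchanged here without a shift beyond the usual scatter, although the step is only modest in size. Nothing measured here explains why the number rises with methoxy.

The compounds shown leave open how a hydrogen, a chlorine or an ethoxy group on this carbon would compare with trifluoromethyl and methoxy. They also leave open whether the step would keep its size if a group other than the 3-methoxyphenyl group stood meta to this carbon.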